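A few compounds are considered here, and "the series" means these few. Any claim that something is new, unique, unknown or untested is made for them only; others in the source may bear on it.

Measured so far:
compound 1 `CCN(CC)C(=S)SCC1=CCOC1=O` — 136000 nM
compound 2 `CNC(=S)SCC1=CCOC1=O` — 85400 nM

In a functional assay on EC9706 cells (Homo sapiens) for antiproliferative activity, read by MTT assay, with a stated time of 72 h (a lower number here means a stronger inhibitor, a higher number a weaker inhibitor), compound 2 gives 85400 nM. Among the compounds with values here, it stands next to compound 1, and the single measured step of a 1.6-fold lower number from compound 1 to compound 2 (0.20 log units; within the scatter) lies within the scatter, so the two numbers cannot be ranked. Compound 3 `CC(C)NC(=S)SCC1=CCOC1=O` differs from compound 2 by isopropyl in place of methyl on an amide-type nitrogen. Within the data shown here, the only step that bears on this change alters the same amide-type nitrogen, diethylamino to methylamino, and stayed within the scatter; no move beyond the scatter is therefore expected. Compound 3 is estimated at 80000 nM, between 35000 nM and 180000 nM, an expected step of a 1.1-fold lower number from compound 2 to compound 3 (0.03 log units; within the scatter).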

Compound 3, half-maximal inhibitory concentration: 59400 nM
For compound 3 the middle estimate is 1.3-fold (0.13 log units) above the measured one, within the range that was stated.
By their numbers in this assay, from the lowest: compounds 3, 2 and 1 (each within the scatter of the next, the first and the last beyond it).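

In this assay, isopropyl in place of methyl on the amide-type nitrogen gives a 1.4-fold lower number from compound 2 to compound 3 (0.16 log units; within the scatter), so this position accepts the branched group without a readable shift. The other new step, a 2.3-fold lower number from compound 1 to compound 3 (0.36 log units; beyond the scatter), is the only one so far beyond the scatter, and it is modest. Nothing available here explains either step.

Still open, as far as these compounds go, is how a longer chain such as n-butyl, a ring such as cyclohexyl, or a chain carrying a carboxylic acid on this nitrogen would read.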